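Hydroxy to hydrogen on the ester side chain

The compounds below may be only part of what the source reports. "The series", "measured", "known", "first", "only" and "open" are said of these compounds alone.

Compound 1 `O=C(CN(c1nc(Cl)nc2[nH]cnc12)C1CC1)N[C@@H](CO)C(=O)OCc1ccccc1` and compound 2 `NC(=O)CC[C@H](NC(=O)CN(c1ncnc2c1ncn2C1CCCCO1)C1CC1)C(=O)OCc1ccccc1` have been tested in a functional assay on the whole organism (Tail, strain ICR) with Mus musculus as the target, in the tail flick test, with a stated time of 60 min, at a dose of 25 umol/kg by the oral route; a lower number here means a weaker effect, a higher number a stronger effect of the compound at the dose given. Compound 1 gives 34.2%, the lower of the two numbers on hand, and compound 2 gives 39.4%; the two numbers lie within the scatter of each other, so no order follows from them. Compound 3 `C[C@H](NC(=O)CN(c1nc(Cl)nc2[nH]cnc12)C1CC1)C(=O)OCc1ccccc1` remains to be measured. It differs from compound 1 by hydrogen in place of hydroxy on a saturated chain carbon, two bonds along the chain from an amide-type nitrogen and a carbonyl carbon. For the measured compounds named here, no measured pair shows this change, so its size is unknown; a step within the scatter is expected, in either direction. Compound 3 is expected to give 31% in this assay, with a range of 12% to 52%. The expected step is a number 3.2 percentage points lower from compound 1 to compound 3 (within the scatter).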

Compound 3, a percentage reported as activity, at one dose (the size of the read-out at that dose, not a potency): 64.3%
Estimate against measurement, compound 3: 33.3 percentage points below; measured number outside the range, above it.
By their numbers in this assay, from the lowest: compounds 1 and 2 (each within the scatter of the next); then compound 3.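

In this assay, this saturated chain carbon proves sensitive to the group it carries: hydrogen in place of hydroxy gives a number 30.1 percentage points higher from compound 1 to compound 3 (beyond the scatter). The earlier compounds shown here offered no pair that isolated this position, so the change now has a measured size, and at this dose methyl reads clearly above hydroxymethyl. Nothing on hand explains the step.

From the compounds shown here alone, whether an ethyl group, a longer chain, an amine or a carboxylic acid at this position would match methyl stays open. So does whether the same step holds on the core of compound 2.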